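The source may hold more compounds than are shown below. What is called first, only, known or untested is meant among the compounds shown, and "the series" means these compounds.

Two compounds share one core and differ only in their side groups. Compound 1 `CCOC(=O)C1=C(C)N/C(=N\C#N)NC1c1ccco1` carries an ethyl ester and a furan-2-yl group, whereas compound 2 `CC1=C(C(=O)OC(C)C)C(c2ccccc2)N/C(=N/C#N)N1` carries an isopropyl ester and a phenyl group. In an assay on HeLa cells for displacement of a labelled ligand from adenosine receptor A3 (Homo sapiens), with a stated time of 180 min, tested at 1 uM (a higher number here means more inhibition at the concentration tested (going by the name of the read-out), a lower number less inhibition), compound 1 gives 20%, and compound 2 gives 6%, the lowest of the two numbers, with compound 1 as its nearest neighbour at a number higher by more than the usual scatter. Compound 1 and compound 2 differ in two places at once. Only their two numbers can be set side by side, and no single change can be read from them.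

Compound 3 `CC1=C(C(=O)OC(C)C)C(c2ccco2)N/C(=N/C#N)N1` takes one step from compound 2: furan-2-yl in place of phenyl on a saturated ring carbon. The isopropyl ester of compound 2 stays, and the furan-2-yl group of compound 1 comes in. Among the compounds with values here, no measured pair isolates this change, so its size can only be guessed. Because compound 1 with the same furan-2-yl group gives 20%, an upward step a number 9 percentage points higher from compound 2 to compound 3 (within the scatter) is expected, possibly no larger than the scatter. Compound 3 is therefore expected to give 15%, within a range from 0% to 32%.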

Compound 3, a percentage reported as inhibition, at one concentration (the size of the read-out at that concentration, not a potency): 4%
Compound 3: middle estimate off by 11 percentage points, on the high side; measured number inside the range.
By their numbers in this assay, from the lowest: compounds 3 and 2 (each within the scatter of the next); then compound 1.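

In this assay, within the data shown here, single changes can now be read for the first time. With the isopropyl ester held in place, furan-2-yl in place of phenyl on a saturated ring carbon gives a number 2 percentage points lower from compound 2 to compound 3 (within the scatter), so these two groups cannot be told apart at this position alongside this ester, and furan-2-yl alone does not bring the higher number of compound 1. With furan-2-yl held in place, the ester is where a step appears: methyl in place of hydrogen, which turns the ethyl ester into the isopropyl ester, gives a number 16 percentage points lower from compound 1 to compound 3 (beyond the scatter), and no measurement at hand offers an explanation for either step.

The compounds shown leave open whether the same ester step would appear with phenyl on the ring carbon, and what a methyl ester or a tert-butyl ester would give. They also leave open whether a thiophen-2-yl or a cyclohexyl group on the saturated ring carbon would separate from the two aromatic rings seen so far.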